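The source may hold more compounds than are shown below. What is called first, only, known or untested is meant among the compounds shown, and "the series" means these compounds.

Working notes on the series. Compound 1 `Cc1ccc(-n2ccnc2SCC(=O)Nc2ccc(C)cc2Br)cc1` is measured in an ADME assay on MT4 cells (Homo sapiens) for cytotoxicity, read by MTT assay (a lower number here means that less compound is tolerated, a higher number that more compound is tolerated), at 80800 nM. Compound 2 `O=C(CSc1nccn1-c1ccc(Cl)cc1)Nc1ccccc1[N+](=O)[O-]` gives only a limit in this assay, > 321000 nM, and this is where it stands, at the limit of > 321000 nM in this assay, at which 1 of the 2 values shown sits. Compound 3 `Cc1ccccc1NC(=O)CSc1nccn1-c1ccc(Cl)cc1` is the next point; it differs from compound 2 by methyl in place of nitro on an aromatic carbon. Among the measured compounds shown here, no measured step covers this change in this assay, and no shift beyond the scatter is expected. Compound 3 is estimated at 200000 nM, within a range from 60000 nM to 400000 nM. The expected step is an at least 1.6-fold lower number from compound 2 to compound 3 (0.20 log units; that floor lies within the scatter).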

Compound 3, half-maximal cytotoxic concentration: 160000 nM
The estimate for compound 3 lay 1.3-fold (0.10 log units) above the measured number; the range from low to high includes it.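

In this assay, among the compounds shown here, methyl in place of nitro, on an aromatic carbon ortho to a large group, gives the first step that can be read: an at least 2.0-fold lower number from compound 2 to compound 3 (0.30 log units; that floor lies within the scatter). With methyl, this position carries a measured number rather than a limit. The step has only a floor and no full size, since compound 2 gives a limit and not a number: the limit of > 321000 nM in this assay, at which 1 of the 3 values shown sits.

As far as these compounds go, how far compound 2 lies past that limit remains open. So does whether an amine or a methoxy group at this position would fall nearer to compound 3 or to compound 2.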